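Compound 3 against the limit of compound 2

The compounds below may be only part of what the source reports. "The series", "measured", "known", "first", "only" and "open" are said of these compounds alone.

Compound 1 `O=C(Nc1cccc(F)c1)c1cc(=O)[nH]c2cc(Br)ccc12`: 7300 nM
Compound 2 `O=C(Nc1cccc(C(F)(F)F)c1)c1cc(=O)[nH]c2cc(Br)ccc12`: > 20000 nM (a limit, not a number)

In a functional assay on KYSE-410 cells (Homo sapiens) for antiproliferative activity, read by MTT assay, with a stated time of 72 h (a lower number here means a stronger inhibitor, a higher number a weaker inhibitor), compound 2 stands only at a limit, > 20000 nM. Compound 3 `O=C(Nc1cccc(OC(F)(F)F)c1)c1cc(=O)[nH]c2cc(Br)ccc12` carries trifluoromethoxy in place of trifluoromethyl on an aromatic carbon. Among the compounds with values here, the one measured step bearing on this is an at least 2.7-fold higher number from compound 1 to compound 2 (0.43 log units; beyond the scatter), with trifluoromethyl in place of fluoro. Its size is only bounded, so it gives a weak guide, and in this assay no step beyond the scatter is expected. Compound 3 may also end at the limit of > 20000 nM in this assay, at which 1 of the 2 values shown sits. The expected change is an at least 1.3-fold lower number from compound 2 to compound 3 (0.12 log units; that floor lies within the scatter). For compound 3 the estimate is 15000 nM, with an expected range of 7000 nM to 30000 nM.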

Compound 3, half-maximal inhibitory concentration: 14000 nM
The estimate for compound 3 lay 1.1-fold (0.03 log units) above the measured number; low and high end bracket the measured number.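

At this position, trifluoromethoxy gives a measured number in this assay, whereas compound 2, with trifluoromethyl, stands only at a limit: the limit of > 20000 nM in this assay, at which 1 of the 3 values shown sits. The change from trifluoromethyl reads an at least 1.4-fold lower number from compound 2 to compound 3 (0.15 log units; that floor lies within the scatter), so it does not separate the two groups. Against fluoro, the change reads a 1.9-fold higher number from compound 1 to compound 3 (0.28 log units; within the scatter), so the step beyond the scatter seen with trifluoromethyl does not recur with trifluoromethoxy.

As far as these compounds go, how far the true value of compound 2 lies past its limit stays open. Also open, from the compounds shown here alone, is whether an amine or a carboxylic acid at this position would move the number beyond the scatter.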